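The compounds below may be only part of what the source reports. "The series", "measured", "known", "first", "only" and "open" are said of these compounds alone.

Compound 3 `Cc1cc(-c2ccco2)c2ncc(CSCCc3ccccc3)n2c1` gives 100 ug/mL in an ADME assay on HEL cells (Homo sapiens) for cytotoxicity, with a stated time of 3 days (on this read-out higher numbers stand for lower toxicity in this test and lower numbers for higher toxicity in this test), level with compound 1 `Cc1cc(-c2ccc(C=O)cc2)cn2c(CSCCc3ccccc3)cnc12` at 100 ug/mL and with compound 2 `Cc1cc(-n2ccnc2)cn2c(CSCCc3ccccc3)cnc12` at 100 ug/mL; no order among the three can be read from these numbers. Among the measured compounds shown here, the one measured step at the same aromatic carbon, no change at the digits printed from compound 1 to compound 2 (within the scatter), stayed within the scatter. Compound 4 `Cc1cc(-n2ccc3cccnc32)c2ncc(CSCCc3ccccc3)n2c1` differs from compound 3 by a group of 9 heavy atoms (7 carbon, 2 nitrogen; one five-membered aromatic ring with 1 hetero atom, one six-membered aromatic ring with 1 hetero atom) in place of a group of 5 heavy atoms (4 carbon, 1 oxygen; one five-membered aromatic ring with 1 hetero atom), on an aromatic carbon. For the measured compounds named here, the replacement of one aromatic substituent by another on this aromatic carbon left the read-out unchanged in the single step available, so a step of no change at the digits printed from compound 3 to compound 4 (within the scatter) of no size beyond the scatter is expected in this assay. Compound 4 is therefore estimated at 100 ug/mL, with a range from 50 ug/mL to 200 ug/mL.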

Compound 4, minimum cytotoxic concentration: 100 ug/mL
The estimate for compound 4 equals the measured number at the digits printed; measured number inside the range.
By their numbers in this assay, from the lowest: compounds 1, 2, 3 and 4 (each within the scatter of the next).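

In this assay, the furan-2-yl group gives way to a larger two-ring group on the aromatic carbon ortho to a fused ring, with no change at the digits printed from compound 3 to compound 4 (within the scatter). Among the compounds shown here, the only earlier step lay at a different aromatic carbon, so the flat read-out now extends to this position and to a substituent with more heavy atoms and an added hydrogen-bond acceptor. No available evidence bears on why the read-out holds here.

Every substituent shown here is an uncharged aromatic ring group. From the compounds shown here alone, an amine or a carboxylic acid on this carbon remains open.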